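A few compounds are considered here, and "the series" means these few. Any claim that something is new, unique, unknown or untested is made for them only; others in the source may bear on it.

Measured so far in an assay on isolated protein for inhibition of Amine oxidase [flavin-containing] A (Homo sapiens), read by fluorescence and spectrophotometry, with a stated time of 20 min; on this read-out higher numbers stand for weaker inhibition and lower numbers for stronger inhibition:
- compound 1 `O=C1/C(=C/c2ccccc2)Cc2cc(O)ccc21`: 1940 nM
- compound 2 `O=C1/C(=C/c2cccc(Cl)c2)Cc2cc(O)ccc21`: 157 nM
- compound 3 `N#Cc1cccc(/C=C2\Cc3cc(O)ccc3C2=O)c1`: 444 nM

Compound 3 holds the second highest of the three numbers in this assay : it sits under compound 1 by a 4.4-fold lower number from compound 1 to compound 3 (0.64 log units; beyond the scatter) and over compound 2 by a 2.8-fold higher number from compound 2 to compound 3 (0.45 log units; beyond the scatter). Compound 4 `O=C1/C(=C/c2cccc(O)c2)Cc2cc(O)ccc21` differs from compound 3 by hydroxy in place of cyano on an aromatic carbon. For the measured compounds named here, the steps seen so far speak only for chloro and cyano on that carbon, a 12-fold lower number from compound 1 to compound 2 (1.09 log units; beyond the scatter) and a 4.4-fold lower number from compound 1 to compound 3 (0.64 log units; beyond the scatter); a hydroxy at this place has no measured counterpart, so the two aromatic substituents that lowered the number need not carry over. A modest step upward from compound 3 is expected, a 1.8-fold higher number from compound 3 to compound 4 (0.26 log units; within the scatter), without confidence in the direction. Compound 4 is estimated at 800 nM, within 250 nM to 2500 nM.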

Compound 4, half-maximal inhibitory concentration: 1200 nM
Beside the measured number, compound 4's estimate is 1.5-fold (0.18 log units) below it, within the range that was stated.
By their numbers in this assay, from the lowest: compound 2; then compound 3; then compounds 4 and 1 (each within the scatter of the next).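

In this assay, hydroxy on this aromatic carbon does not match chloro or cyano: a 2.7-fold higher number from compound 3 to compound 4 (0.43 log units; beyond the scatter), and a 7.6-fold higher number from compound 2 to compound 4 (0.88 log units; beyond the scatter). Hydroxy cannot be told apart from hydrogen here, a 1.6-fold lower number from compound 1 to compound 4 (0.21 log units; within the scatter), so a substituent at this place does not by itself separate a compound from compound 1. No evidence is available to explain the differences among these substituents.

Open, as far as these compounds go, is whether bromo, methoxy or an amine at this aromatic carbon would track chloro or hydroxy. Also open, from the compounds shown here alone, is what the hydroxy on the shared core contributes to these numbers.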